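Swapping an Aromatic Amide Group for Cyclohexyl

This account rests on a few compounds, and the source may have more. Where it says the series, first, only, none or still open, it means among the compounds named here.

Compound 1 `O=C(CCCCCN(CC(=O)NC1CCCCC1)C(=O)c1ccccc1)NO`: 3460 nM
Compound 2 `Cc1ccc(NC(=O)CN(CCCCCC(=O)NO)C(=O)c2cc(C)cc(C)c2)cc1`: 1270 nM

In a functional assay on A2780 cells (Homo sapiens) for cytotoxicity, read by MTT assay, with a stated time of 72 h (on this read-out lower numbers stand for stronger inhibition and higher numbers for weaker inhibition), compound 2 at 1270 nM holds the lower of the two numbers, and the gap to compound 1 at 3460 nM lies beyond the usual scatter. The next compound, compound 3 `Cc1cc(C)cc(C(=O)N(CCCCCC(=O)NO)CC(=O)NC2CCCCC2)c1`, has cyclohexyl in place of 4-methylphenyl on an amide-type nitrogen. For the measured compounds named here, no measured pair shows this change on its own, so its size can only be judged loosely. Going by the values given here, the only other number available as a guide is that of compound 1 at 3460 nM. A modest rise in this assay is therefore expected, meaning weaker inhibition, though no change beyond the scatter remains possible. The expected step, a 1.7-fold higher number from compound 2 to compound 3 (0.22 log units; within the scatter), is small to moderate. For compound 3 the estimated value is 2100 nM, with an expected range of 900 nM to 4800 nM.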

Compound 3, half-maximal inhibitory concentration: 160 nM
Compound 3: middle estimate off by 13-fold (1.12 log units), on the high side; measured number outside the range, below it.
By their numbers in this assay, from the lowest: compound 3; then compound 2; then compound 1.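

With the 3,5-dimethylphenyl group held constant, the change on the amide-type nitrogen from 4-methylphenyl to cyclohexyl gives a 7.9-fold lower number from compound 2 to compound 3 (0.90 log units; beyond the scatter) in this assay and shows that an aromatic ring is not needed at this position. With cyclohexyl held constant, 3,5-dimethylphenyl in place of phenyl on a carbonyl carbon gives a 22-fold lower number from compound 1 to compound 3 (1.33 log units; beyond the scatter) in the same assay, so the group on the other side of the nitrogen also strongly affects the number. No measurement shown explains either step.

As far as these compounds go, it remains open whether a smaller ring such as cyclopentyl or an open chain such as n-hexyl would serve as well as cyclohexyl. Also open, from the compounds shown here alone, is whether 3,5-dimethylphenyl would give a similar step with 4-methylphenyl on the amide-type nitrogen.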